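Compound 3 to compound 4: methyl to isopropyl

The source may report more compounds than this note shows. Statements on the series, on what has been measured and on what is new or still open speak of the compounds shown alone.

In a functional assay on MIA PaCa-2 cells (Homo sapiens) for inhibition, read by MTT assay, with a stated time of 3 days (on this read-out higher numbers stand for weaker inhibition and lower numbers for stronger inhibition), compound 3 `CCN(CC)S(=O)(=O)c1ccc(S(=O)(=O)N2CCC[C@@H](C(=O)N3CCN(c4nc(C)no4)CC3)C2)cc1` reads > 10000 nM as a limit, not a number. Compound 1 `CCN(CC)S(=O)(=O)c1ccc(S(=O)(=O)N2CCC[C@@H](C(=O)N3CCN(c4nc(C(F)(F)F)no4)CC3)C2)cc1` reads > 10000 nM as a limit as well. Compound 2 `CC(C)c1noc(N2CCN(C(=O)[C@@H]3CCCN(S(=O)(=O)c4ccc(S(=O)(=O)C5CCC5)cc4)C3)CC2)n1` differs elsewhere in the molecule, carries 3-isopropyl-1,2,4-oxadiazol-5-yl and reads > 10000 nM as a limit too. Among the compounds with values here, the series so far therefore offers only the limit of > 10000 nM in this assay, at which 3 of the 3 values shown sit, and no number from which to rank the compounds.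

Compound 4 `CCN(CC)S(=O)(=O)c1ccc(S(=O)(=O)N2CCC[C@@H](C(=O)N3CCN(c4nc(C(C)C)no4)CC3)C2)cc1` replaces the methyl of compound 3 with isopropyl (isopropyl in place of methyl on an aromatic carbon) on an aromatic carbon of a five-membered aromatic ring with 2 nitrogen and 1 oxygen, two ring bonds from the ring oxygen. Within the data shown here, the only measured step at this place is a step that the two limits leave unreadable from compound 1 to compound 3 and it gives no size to carry over. The closest other evidence is compound 2 at > 10000 nM as a limit, which shows the isopropyl group on a compound without a readable value.

No step beyond the scatter is expected in either direction, and the estimated step that the limit leaves unreadable from compound 3 to compound 4 should leave compound 4 most likely reported as a limit again. For compound 4 the expected value is 12000 nM within an estimated range of 6000 nM to 30000 nM if a number is reported at all.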

Compound 4, half-maximal inhibitory concentration: > 10000 nM
Compound 4 ended at the assay's limit; the forecaster's own chance of this, stated with the estimate: 90%; the middle value is on the limit's open side.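

No step can be read from compound 4 to compound 1, compound 2 or compound 3 in this assay, and the series offers only one limit, not a number: the limit of > 10000 nM in this assay, at which 4 of the 4 values shown sit.

The compounds shown leave open whether trifluoromethyl, methyl or isopropyl on the aromatic carbon, or diethylamino or cyclobutyl on the sulfonyl sulfur, changes inhibition at all.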